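This account rests on a few compounds, and the source may have more. Where it says the series, first, only, none or still open, it means among the compounds named here.

Compound 1 `Fc1ccc(-c2ccc3c(NCCCNCc4ccco4)ccnc3c2)cc1` carries a 4-fluorophenyl group on the shared core and a furan-2-yl on a saturated chain carbon bound to an amine nitrogen. In an ADME assay on HepG2 cells (Homo sapiens) for cytotoxicity, read by luminescence, CellTiter-Glo and ATP content, with a stated time of 72 h (on this read-out higher numbers stand for an effect only at larger amounts of compound and lower numbers for an effect already at smaller amounts), compound 1 gives 7760 nM, the highest of the three numbers measured. Compound 2 `COc1cccc(CNCCCNc2ccnc3cc(Cc4ccccc4)ccc23)c1O` gives 5720 nM, which lies within the scatter of compound 1, so the two cannot be told apart. Going by the values given here, compound 3 `COc1ccc(F)cc1CNCCCNc1ccnc2cc(-c3ccc(F)cc3)ccc12` gives 770 nM, and the single change at the chain carbon brought a 10-fold lower number from compound 1 to compound 3 (1.00 log units; beyond the scatter).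

Compound 4 `N#Cc1ccc(Cc2ccc3c(NCCCNCc4ccco4)ccnc3c2)cc1` has not yet been measured. It differs from compound 1 in one place: 4-cyanobenzyl in place of 4-fluorophenyl on an aromatic carbon. Among the compounds with values here, no measured step touches this spot on the core; the only measured step, from compound 1 to compound 3, alters the chain end instead. Within the data shown here, compound 2 and compound 3 differ from each other in more than one place, so their two values show only that the core position has not been tested on its own. Among the measured compounds shown here, with no step on this position to lean on, no move beyond the scatter is expected. Compound 4 is therefore expected to give 7000 nM, somewhere between 2500 nM and 20000 nM. This amounts to an expected 1.1-fold lower number from compound 1 to compound 4 (0.04 log units; within the scatter).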

Compound 4, half-maximal effective concentration: 7910 nM
For compound 4 the middle estimate is 1.1-fold (0.05 log units) below the measured one; the measured number falls inside the stated range.
By their numbers in this assay, from the lowest: compound 3; then compounds 2, 1 and 4 (each within the scatter of the next).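

Going by these compounds alone, this is the first step that touches this spot on the shared core: in this assay, 4-cyanobenzyl in place of 4-fluorophenyl on an aromatic carbon gives a 1.0-fold higher number from compound 1 to compound 4 (0.01 log units; within the scatter), so the two compounds cannot be told apart. The swap brings in a nitrile and a larger group overall, yet with furan-2-yl at the chain end this position shows no effect that can be read here, whereas the change at the chain end gives a 10-fold lower number from compound 1 to compound 3 (1.00 log units; beyond the scatter), a step beyond the scatter. Nothing measured alongside these numbers offers a reason for this flat result.

Whether the same swap would stay just as flat with the 5-fluoro-2-methoxyphenyl chain end of compound 3, the one chain end shown to go with a clearly lower number, remains open. Also open, as far as these compounds go, is how a quite different group on this aromatic carbon, such as a carboxylic acid, a primary amine or a longer saturated chain, would read in this assay, since both groups compared here carry a six-membered aromatic ring of carbon only.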